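The source may hold more compounds than are shown below. What is called first, only, known or untested is meant among the compounds shown, and "the series" means these compounds.

Measured compounds:
- compound 1 `Cc1ccc2nc(NC(c3cn(-c4ccccc4)nc3-c3cccc([N+](=O)[O-])c3)c3c(O)ccc4ccccc34)sc2c1`: 57400 nM
- compound 2 `Cc1cc2nc(NC(c3cn(-c4ccccc4)nc3-c3ccc([N+](=O)[O-])cc3)c3c(O)ccc4ccccc34)sc2cc1C`: 41900 nM
- compound 3 `O=[N+]([O-])c1ccc(-c2nn(-c3ccccc3)cc2C(Nc2nc3ccc(Cl)cc3s2)c2c(O)ccc3ccccc23)cc1`: 57200 nM

In a functional assay on A549 cells (Homo sapiens) for antiproliferative activity, read by MTT assay, with a stated time of 48 h (on this read-out higher numbers stand for weaker inhibition and lower numbers for stronger inhibition), compound 3 gives 57200 nM, level with compound 1 and within the scatter of compound 2, so the three values form one tight group. The next compound, compound 4 `Cc1ccc2nc(NC(c3cn(-c4ccccc4)nc3-c3ccc([N+](=O)[O-])cc3)c3c(O)ccc4ccccc34)sc2c1`, differs from compound 3 at a single place, methyl in place of chloro on an aromatic carbon, turning 6-chloro-1,3-benzothiazol-2-yl into 6-methyl-1,3-benzothiazol-2-yl. Within the data shown here, one measured step bears on this exchange, a 1.4-fold higher number from compound 2 to compound 3 (0.14 log units; within the scatter), where 6-chloro-1,3-benzothiazol-2-yl replaces 5,6-dimethyl-1,3-benzothiazol-2-yl. Compound 4 also shares the 6-methyl-1,3-benzothiazol-2-yl group with compound 1, which gives 57400 nM although it differs elsewhere. Nothing beyond the scatter is therefore expected in this assay, and the estimated change is a 1.1-fold lower number from compound 3 to compound 4 (0.06 log units; within the scatter). The expected value for compound 4 is 50000 nM, with an estimated range from 28000 nM to 85000 nM.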

Compound 4, half-maximal inhibitory concentration: 29000 nM
Compound 4: the middle estimate sits 1.7-fold (0.24 log units) above what was measured; low and high end bracket the measured number.
By their numbers in this assay, from the lowest: compounds 4, 2, 3 and 1 (each within the scatter of the next).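

With 6-methyl-1,3-benzothiazol-2-yl in place of 6-chloro-1,3-benzothiazol-2-yl, this assay shows a 2.0-fold lower number from compound 3 to compound 4 (0.29 log units; within the scatter), so exchanging chloro for methyl at this position stays within the scatter. Hydrogen in place of methyl on the aromatic carbon of the 5,6-dimethyl-1,3-benzothiazol-2-yl group gives a 1.4-fold lower number from compound 2 to compound 4 (0.16 log units; within the scatter), so the 6-methyl and 5,6-dimethyl groups cannot be told apart here. The first direct reading on the nitrophenyl group, 4-nitrophenyl in place of 3-nitrophenyl, gives a 2.0-fold lower number from compound 1 to compound 4 (0.30 log units; within the scatter), which also stays within the scatter, so neither place has yet shown a change beyond it.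

From the compounds shown here alone, whether an amine, a methoxy group or a carboxylic acid at the 6-position, or an amine in place of the nitro group, would move the number beyond the scatter remains open. No measurement at hand offers an explanation for any of these numbers.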